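Benzyl variants on a shared core: toward compound 4

This account rests on a few compounds, and the source may have more. Where it says the series, first, only, none or still open, it means among the compounds named here.

Measured so far in a functional assay on G-361 cells (Homo sapiens) for antiproliferative activity, with a stated time of 72 h; a higher number here means a weaker inhibitor, a lower number a stronger inhibitor
- compound 1 `OC[C@H]1O[C@@H](n2cnc3c(NCc4ccccc4Cl)ncnc32)[C@H](O)[C@@H]1O` gives "not determined" (no result reported)
- compound 2 `OC[C@H]1O[C@@H](n2cnc3c(NCc4ccc(Br)cc4)ncnc32)[C@H](O)[C@@H]1O` gives > 166000 nM (a limit, not a number)
- compound 3 `Cc1ccc(CNc2ncnc3c2ncn3[C@@H]2O[C@H](CO)[C@@H](O)[C@H]2O)cc1` gives "not determined" (no result reported)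

Compound 3 has no position on the scale in this assay, since compound 3 gives "not determined" (no result reported) and so offers no number to start from. Compound 1 gives "not determined" (no result reported) and adds nothing either. Among the compounds with values here, the only result comes from compound 2, which gives > 166000 nM, and this is a limit of the assay rather than a number.

Compound 4 `COc1ccccc1CNc1ncnc2c1ncn2[C@@H]1O[C@H](CO)[C@@H](O)[C@H]1O` is still to be measured. The change is 2-methoxyphenyl in place of 4-methylphenyl on a saturated chain carbon bound to a nitrogen on an aromatic ring, with 2-methoxyphenyl in place of 4-methylphenyl on a saturated chain carbon bound to a nitrogen on an aromatic ring. Within the data shown here, no measured step gives a size for such a change, so none can be read across. Among the measured compounds shown here, with compound 3 lacking a number, no step from it can be stated, and the expectation rests on compound 2 at > 166000 nM alone. Compound 4 is therefore expected to be similarly inactive, and a report of only a limit would be unsurprising.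

If a number is obtained, the estimated value for compound 4 is 120000 nM, with an expected range from 25000 nM to 200000 nM.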

Compound 4, half-maximal inhibitory concentration: > 166000 nM
Compound 4: only a limit was reported (the forecaster's own chance of this, stated with the estimate: 60%); middle value at least 1.3-fold (0.14 log units) from the limit.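

In this assay compound 4 gives > 166000 nM, a limit of the assay and not a number. Compound 2 also gives only a limit, so no step can be read between compound 2 and compound 4: the limit of > 166000 nM in this assay, at which 2 of the 4 values shown sit.

The compounds shown leave open whether any benzyl variant on the shared core reaches a numerical value in this assay.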